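Reversing the amide on the pyrazole core: compound 3 in view

The compounds below may be only part of what the source reports. "The series", "measured", "known", "first", "only" and "open" are said of these compounds alone.

Two compounds from this series have been characterised in an assay on CHO-K1 cells for displacement of a labelled ligand from prostaglandin E2 receptor EP1 subtype (Homo sapiens); on this read-out higher numbers stand for weaker inhibition and lower numbers for stronger inhibition. Compound 1 `Cc1cc(C(=O)Nc2cccc(F)c2)nn1Cc1cc(Cl)ccc1OCc1ccccc1` gives 200 nM in this assay, and compound 2 `Cc1cc(C(=O)NN2CCOCC2)nn1Cc1cc(Cl)ccc1OCC(C)C` gives 251 nM. Compound 1 thus shows the lower of the two numbers, but the gap to compound 2 lies within the scatter, so the two cannot be told apart on these data.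

The next compound, compound 3 `Cc1cc(NC(=O)C2CCCO2)nn1Cc1cc(Cl)ccc1OCc1ccccc1`, keeps the core of compound 1 and differs from it in a single place: ((oxolan-2-yl)carbonyl)amino in place of (3-fluorophenyl)carbamoyl on an aromatic carbon. Among the compounds with values here, no measured pair of compounds shares this change, so its size is unknown. Given that the new group is smaller and lacks the aromatic ring of the group it replaces, a modest weakening is expected, with the step from compound 1 to compound 3 in this assay estimated at a 3.0-fold higher number from compound 1 to compound 3 (0.48 log units; beyond the scatter). Compound 3 is therefore expected to give about 600 nM in this assay, with a likely range from 150 nM to 2500 nM.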

Compound 3, half-maximal inhibitory concentration: 39.8 nM
For compound 3 the middle estimate is 15-fold (1.18 log units) above the measured one; measured number below the stated range.
By their numbers in this assay, from the lowest: compound 3; then compounds 1 and 2 (each within the scatter of the next).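

This position on the five-membered aromatic ring proves open to change in this assay: ((oxolan-2-yl)carbonyl)amino in place of (3-fluorophenyl)carbamoyl gives a 5.0-fold lower number from compound 1 to compound 3 (0.70 log units; beyond the scatter), a step beyond the scatter. The six-membered aromatic ring of the leaving group is therefore not required for a lower number here, and the amide can attach to the core through its nitrogen rather than its carbonyl. No measurement shown here accounts for the size of this step.

The compounds shown leave open how much of the step belongs to the reversed amide and how much to the oxolane ring, as both change at once. An acetylamino group or a (3-fluorobenzoyl)amino group on this carbon would help separate the two contributions.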